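The source may report more compounds than this note shows. Statements on the series, on what has been measured and on what is new or still open speak of the compounds shown alone.

In a physicochemical assay for solubility (a lower number here means a less soluble compound, a higher number a more soluble compound), compound 1 `CNC(=O)c1cc(C(=O)NC2CC2)cc2c1OC[C@H]2c1ccccc1` reads >= 190 ug/mL, which is a limit of the assay and not a number. Among the compounds with values here, compound 2 `CNC(=O)c1cc(C(=O)N[C@@H]2C[C@H]2C)cc2c1O[C@H](CF)[C@H]2c1ccccc1` gives 7 ug/mL, the only exact reading so far in this assay and the lower of the two results. Compound 3 `CNC(=O)c1cc(C(=O)NC2CC2)cc2c1O[C@H](CF)[C@H]2c1ccccc1` has hydrogen in place of methyl on a saturated ring carbon, so 2-methylcyclopropyl becomes cyclopropyl. Within the data shown here, no measured pair isolates this change, so only a modest rise, near the edge of the scatter, is expected. The expected step is a 2.1-fold higher number from compound 2 to compound 3 (0.33 log units; beyond the scatter). Compound 3 is estimated at 15 ug/mL, with an expected range of 6 ug/mL to 60 ug/mL.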

Compound 3, solubility: 8 ug/mL
Estimate against measurement, compound 3: 1.9-fold (0.27 log units) above, within the range that was stated.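

In this assay hydrogen in place of methyl on the three-membered ring reads as a 1.1-fold higher number from compound 2 to compound 3 (0.06 log units; within the scatter) and so does not tell 2-methylcyclopropyl from cyclopropyl. With cyclopropyl held constant, fluoromethyl in place of hydrogen on a saturated ring carbon reads as an at least 23-fold lower number from compound 1 to compound 3 (1.37 log units; beyond the scatter) and is the only step shown beyond the scatter. That size is only a bound, as compound 1 stands at a limit of the assay and not at a number: the limit of >= 190 ug/mL in this assay, at which 1 of the 3 values shown sits.

Left open is how far compound 1 lies past its limit. Also open, on these data alone, is whether a hydroxymethyl or an amine in place of the fluoromethyl would read nearer compound 1 or compound 3.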